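The source may hold more compounds than are shown below. What is called first, only, known or untested is meant among the compounds shown, and "the series" means these compounds.

Compound 1 (`CC(=O)OC/C1=C/C[C@](C)(CCC=C(C)C)/C=C/[C@@H](OC(=O)C=C(C)C)[C@](C)(O)/C=C/C1=O`) gives 4510 nM in a functional assay on MCF7 cells (Homo sapiens) for antiproliferative activity, read by MTT assay, with a stated time of 48 h (on this read-out lower numbers stand for stronger inhibition and higher numbers for weaker inhibition), and so sits close to compound 3 (`C=C1/C=C/C(=O)/C(CO)=C\C[C@](C)(CCC=C(C)C)/C=C/[C@H]1OC(=O)C=C(C)C`) at 2750 nM, a gap within the usual scatter, which means the two cannot be told apart. Compound 2 (`CO[C@]1(C)/C=C/C(=O)/C(CO)=C\C[C@](C)(CCC=C(C)C)/C=C/[C@H]1OC(=O)C=C(C)C`) gives 14300 nM, a number clearly higher than that of compound 1, which means weaker inhibition. The compound still to be measured, compound 4 (`CCN(CC)C/C1=C/C[C@](C)(CCC=C(C)C)/C=C/[C@@H](OC(=O)C=C(C)C)[C@](C)(O)/C=C/C1=O`), differs from compound 1 in one place: it carries diethylamino in place of acetoxy on a saturated chain carbon bound to a double-bonded ring carbon. Among the measured compounds shown here, no measured pair of compounds shows this exchange, so the data give no direct guide to its effect. The expectation in this assay is therefore no step beyond the scatter, and the estimated move is a 1.3-fold lower number from compound 1 to compound 4 (0.11 log units; within the scatter), with real uncertainty in either direction. For compound 4 the estimated value is 3500 nM, with an expected range from 1200 nM to 12000 nM for repeated measurements.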

Compound 4, half-maximal inhibitory concentration: 130 nM
Estimate against measurement, compound 4: 27-fold (1.43 log units) above, and the stated range ends above it.
By their numbers in this assay, from the lowest: compound 4; then compounds 3 and 1 (each within the scatter of the next); then compound 2.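

In this assay, diethylamino in place of acetoxy on a saturated chain carbon bound to a double-bonded ring carbon gives a 35-fold lower number from compound 1 to compound 4 (1.54 log units; beyond the scatter) on an otherwise unchanged core. Among the compounds shown here, this is the first pair here that differs in one place, and it shows that the group at this position can strongly change the antiproliferative read-out. The data offer no measured basis for explaining the size of this step.

On these data alone, whether a smaller amine such as dimethylamino or a ring amine such as morpholine would give a number like that of compound 4 remains open, as does whether any amine would do or only diethylamino. As far as these compounds go, it is also open whether the same exchange would bring a similar step on the core of compound 2.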